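A Halogen Exchange on the Aryl Piperazine

The source may hold more compounds than are shown below. What is called first, only, known or untested is meant among the compounds shown, and "the series" means these compounds.

Of the compounds shown here, two on a shared core have been measured in a functional assay on HEK293 cells for positive allosteric modulation of metabotropic glutamate receptor 2 (Homo sapiens), read by a luciferase reporter and cAMP accumulation, in the presence of a further agent that is not named here; on this read-out lower numbers stand for an effect already at smaller amounts and higher numbers for an effect only at larger amounts of compound. Compound 1 `Fc1cc(Cl)ccc1N1CCN(Cc2ccn3c(CC4CC4)nnc3c2C(F)(F)F)CC1` gives 8.3 nM in this assay. Compound 2 `Fc1ccc(C2CCN(Cc3ccn4c(CC5CC5)nnc4c3C(F)(F)F)CC2)c(F)c1` gives 20 nM in this assay. Compound 1 holds the lowest of the two numbers; its nearest neighbour is compound 2, whose higher number lies beyond the usual scatter. Among the measured compounds shown here, no step between measured compounds that differ in a single place is available, so this pair shows only what its two values show.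

Compound 3 `Fc1ccc(N2CCN(Cc3ccn4c(CC5CC5)nnc4c3C(F)(F)F)CC2)c(F)c1` has not yet been measured in this assay. It differs from compound 1 in one place: fluoro in place of chloro on an aromatic carbon. Read one bond further out, 4-chloro-2-fluorophenyl becomes 2,4-difluorophenyl. For the measured compounds named here, no measured step covers this exchange. In this assay compound 3 is expected to give a somewhat higher number than compound 1, a step of a 1.8-fold higher number from compound 1 to compound 3 (0.26 log units; within the scatter) of modest size that may not exceed the scatter. The estimate for compound 3 in this assay is 15 nM, with a range from 5 nM to 45 nM.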

Compound 3, half-maximal effective concentration in the metabotropic glutamate receptor 2 assay: 166 nM
The estimate for compound 3 lay 11-fold (1.04 log units) below the measured number, and the stated range ends below it.
By their numbers in the metabotropic glutamate receptor 2 assay, from the lowest: compound 1; then compound 2; then compound 3.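

In the metabotropic glutamate receptor 2 assay, fluoro in place of chloro on this aromatic carbon, para to a large group, gives a 20-fold higher number from compound 1 to compound 3 (1.30 log units; beyond the scatter). Compound 2 and compound 1 had shown nothing about this position, and the exchange of one halogen for another, a change of a single heavy atom with no change in donors, acceptors or charge, now proves to be far from a minor edit here. In a physicochemical assay for lipophilicity, read by HPLC, in phosphate buffer, measured as octanol-water partition, at pH 7.4 (a higher number here means a more lipophilic compound, a lower number a more polar compound), compound 1 gives 4.01 and compound 3 gives 3.2. The step in the receptor read-out comes with a drop in the physicochemical assay, and this lower lipophilicity is the only measured property that may account for the weaker result, although a single pair cannot establish that link: the measured distribution coefficient of compound 1, 4.01, and of compound 3, 3.2, a number 0.81 log units lower (beyond the scatter)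

The compounds shown leave open whether the receptor read-out follows lipophilicity at this position or depends on chloro itself, a question that bromo, methyl or trifluoromethyl on the same carbon would help to settle. They also leave open whether the same exchange would have a step of similar size in the metabotropic glutamate receptor 2 assay with a group other than the aryl piperazine of compound 1 on the shared core.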